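The source may report more compounds than this note shows. Statements on the series, on what has been measured and on what is new or still open speak of the compounds shown alone.

Measured compounds so far:
compound 1, `COc1ccc(/C=C2\SC(=O)N(Cc3ccc(C)cc3)C2=O)cc1`, 58.8%
compound 2, `Cc1ccc(CN2C(=O)S/C(=C\c3ccc(Cl)cc3)C2=O)cc1`, 48%

Going by the values given here, in a functional assay on the whole organism (plasma) with Mus musculus as the target, with a stated time of 15 days, at a dose of 30 mg/kg by the oral route (a higher number here means a stronger effect of the compound at the dose given, a lower number a weaker effect), compound 2 gives the lower of the two numbers recorded; the only measured step is a number 10.8 percentage points lower from compound 1 to compound 2 (beyond the scatter), which rests on chloro in place of methoxy on an aromatic carbon and is modest. Compound 3, `Cc1ccc(CN2C(=O)S/C(=C\OCc3ccccc3)C2=O)cc1`, differs from compound 2 by benzyloxy in place of 4-chlorophenyl on a double-bonded chain carbon bound to a double-bonded ring carbon. Among the compounds with values here, this change swaps out the whole 4-chlorophenyl group rather than a substituent on it, so the one measured step bears on it only loosely: it shows that a change at this end of the shared core shifts the read-out modestly, without pointing to a direction for so different a group. The account therefore expects compound 3 to move by a number 6 percentage points lower from compound 2 to compound 3 (within the scatter), a step not beyond the scatter. The estimated value of compound 3 in this assay is 42%, within a range from 22% to 62%.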

Compound 3, a percentage reported as activity, at one dose (the size of the read-out at that dose, not a potency): 42.1%
The estimate for compound 3 lay 0.1 percentage points below the measured number; measured number inside the range.
By their numbers in this assay, from the lowest: compounds 3 and 2 (each within the scatter of the next); then compound 1.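

In this assay, the place on a double-bonded chain carbon bound to a double-bonded ring carbon admits a change of the whole group and not only of a substituent: benzyloxy in place of 4-chlorophenyl gives a number 5.9 percentage points lower from compound 2 to compound 3 (within the scatter) and so does not separate the two groups. Benzyloxy in place of 4-methoxyphenyl gives a number 16.7 percentage points lower from compound 1 to compound 3 (beyond the scatter) and, with the step to compound 2 also beyond the scatter, compound 1 stands apart from both other compounds. Nothing on hand accounts for these numbers.

The compounds shown leave open whether the oxygen of benzyloxy matters, which a plain benzyl group at this place could test. They also leave open whether an amine or a carboxylic acid on the phenyl ring would give a number near that of compound 1.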